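Trimethoxyphenyl replacing methoxyphenyl on the core of compound 3

A few compounds are considered here, and "the series" means these few. Any claim that something is new, unique, unknown or untested is made for them only; others in the source may bear on it.

Compound 3 `COc1ccc(C(=O)/C=C/c2cc(-c3ccc(OC)cc3)n3nc(-c4ccccc4)cc3n2)cc1` gives the lowest number of the three measured in a functional assay on MDA-MB-231 cells (Homo sapiens) for antiproliferative activity, read by MTT assay, with a stated time of 24 h (a higher number here means a weaker inhibitor, a lower number a stronger inhibitor), at 6300 nM. Compound 2 `COc1cc(-c2cc(/C=C/C(=O)c3ccc(C)c(C)c3)nc3cc(-c4ccccc4)nn23)cc(OC)c1OC` gives 13500 nM and compound 1 `COc1ccc(C(=O)/C=C/c2cc(-c3cc(OC)c(OC)c(OC)c3)n3nc(-c4ccccc4)cc3n2)cc1OC` gives 18300 nM; both steps up from compound 3 lie beyond the scatter. Compound 4 `COc1ccc(C(=O)/C=C/c2cc(-c3cc(OC)c(OC)c(OC)c3)n3nc(-c4ccccc4)cc3n2)cc1` changes compound 3 by 3,4,5-trimethoxyphenyl in place of 4-methoxyphenyl on an aromatic carbon. Going by the values given here, no measured step covers this change alone: the one single-point step, a 1.4-fold lower number from compound 1 to compound 2 (0.13 log units; within the scatter), concerns the group on the carbonyl carbon and is within the scatter. Compound 1 and compound 2, which both carry 3,4,5-trimethoxyphenyl on the core, give higher numbers than compound 3, but they also differ from compound 3 on the carbonyl carbon. Compound 4 is therefore expected to move toward them, with a 1.7-fold higher number from compound 3 to compound 4 (0.24 log units; within the scatter) as the estimated step. For compound 4 the expected value is 11000 nM, in the range 4500 nM to 27000 nM.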

Compound 4, half-maximal inhibitory concentration: 13200 nM
Compound 4: the middle estimate sits 1.2-fold (0.08 log units) below what was measured, and the stated range covers the measured number.
By their numbers in this assay, from the lowest: compound 3; then compounds 4, 2 and 1 (each within the scatter of the next).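

In this assay, going by these compounds alone, the change to 3,4,5-trimethoxyphenyl on the core gives a 2.1-fold higher number from compound 3 to compound 4 (0.32 log units; beyond the scatter) and so isolates this position for the first time. With that group in place, the carbonyl-side changes give a 1.0-fold lower number from compound 2 to compound 4 (0.01 log units; within the scatter) and a 1.4-fold lower number from compound 1 to compound 4 (0.14 log units; within the scatter) and do not separate the three aryl groups there. No measured evidence accounts for the step at the core.

On these data alone, whether the carbonyl-side groups separate when 4-methoxyphenyl sits on the core stays open. So does the effect of a hydroxy group or an amine on the aryl ring at the core position.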